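Fluorine on the amide aryl ring of a thiophene-carboxamide

The source may report more compounds than this note shows. Statements on the series, on what has been measured and on what is new or still open speak of the compounds shown alone.

Compound 1 `NC(=O)c1c(NC(=O)c2ccccc2Cl)sc2c1CCN(Cc1ccccc1)C2` was tested in a functional assay on MKN-74 cells (Homo sapiens) for antiproliferative activity, with a stated time of 24 h (on this read-out higher numbers stand for weaker inhibition and lower numbers for stronger inhibition), and, in that setting, compound 1 gave 14500 nM. Compound 2 `NC(=O)c1c(NC(=O)c2ccccc2Cl)sc2c1CCN(Cc1ccccc1F)C2` carries one alteration relative to compound 1, namely (fluoro in place of hydrogen on an aromatic carbon), and compound 2 gave 12900 nM in this assay. The change is a 1.1-fold lower number from compound 1 to compound 2 (0.05 log units; within the scatter).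

Compound 3 `NC(=O)c1c(NC(=O)c2ccccc2)sc2c1CCN(C(=S)Nc1ccccc1Cl)C2` has a different core; the difference between the two cores is not broken down here. In this assay compound 3 gave 11800 nM, a value that sits close to those of compound 1 and compound 2.

Compound 4 `NC(=O)c1c(NC(=O)c2ccccc2F)sc2c1CCN(C(=S)Nc1ccccc1Cl)C2` has not yet been measured. It differs from compound 3 by fluoro in place of hydrogen on an aromatic carbon. This is the same change that separates compound 2 from compound 1, and the described surroundings of the place are the same in both pairs, although the ring that receives the fluorine belongs to a different part of the molecule in each case, so it is best regarded as the same kind of change on another core.

Because the earlier occurrence of this change produced only a 1.1-fold lower number from compound 1 to compound 2 (0.05 log units; within the scatter), compound 4 is expected to stay near compound 3, and the estimated step is a 1.1-fold lower number from compound 3 to compound 4 (0.03 log units; within the scatter). On that basis compound 4 is estimated to give 11000 nM in this assay, with a range from 5000 nM to 25000 nM.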

Compound 4, half-maximal inhibitory concentration: 11100 nM
Beside the measured number, compound 4's estimate is 1.0-fold (0.00 log units) below it, and the stated range covers the measured number.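

In this assay, fluoro in place of hydrogen on an aromatic carbon gave a 1.1-fold lower number from compound 3 to compound 4 (0.03 log units; within the scatter). Set beside its earlier occurrence, the step on the second core agrees with the first: the same change on two cores in this assay, a 1.1-fold lower number (0.05 log units; within the scatter) from compound 1 to compound 2 and a 1.1-fold lower number (0.03 log units; within the scatter) from compound 3 to compound 4, 1.1-fold (0.02 log units) apart, within the scatter of two such steps. This shows that, in these two pairs, the change left the antiproliferative read-out within the scatter on both cores, so the small step seen on the core of compound 1 also held on the core of compound 3; it does not show that the same would hold on any other core, and since neither step stands out from the scatter, the pairs cannot tell whether a real effect of the change carries over, while the fluorine also sits on a different part of the molecule in each pair, so the same site has not been tested twice.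

The compounds shown leave open whether a different group at the place taken by the fluoro in compound 4, such as a methoxy group, a nitrile or an amine, would move the number beyond the scatter on either core. They also leave open what a carboxylic acid in place of the carboxamide shared by all four compounds would do in this read-out.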